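Trimming the amide chain: propanoyl to acetyl

The source may report more compounds than this note shows. Statements on the series, on what has been measured and on what is new or still open speak of the compounds shown alone.

Measured so far:
Compound 1 `CC(=O)N[C@@H]1CCCc2c1cncc2N1C(=O)c2ccc(Cl)cc2[C@@H]1C1CC1`: 354 nM
Compound 2 `CCC(=O)N[C@@H]1CCCc2c1cncc2N1C(=O)c2ccc(Cl)cc2[C@@H]1C`: 6 nM

In an assay on cells for inhibition of cytochrome P450 11B2, mitochondrial (Homo sapiens), read by HTRF (on this read-out higher numbers stand for weaker inhibition and lower numbers for stronger inhibition), compound 2 gives 6 nM and compound 1 gives 354 nM. Compound 2 thus holds the lower of the two numbers, with compound 1 far higher and well beyond the scatter; compound 1 differs from compound 2 in two places, so the two values alone do not tell which difference matters.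

Compound 3 `CC(=O)N[C@@H]1CCCc2c1cncc2N1C(=O)c2ccc(Cl)cc2[C@@H]1C` differs from compound 2 in one place: hydrogen in place of methyl on a saturated chain carbon bound to a carbonyl carbon. Among the measured compounds shown here, no measured pair shows this change on its own. A shortening of one carbon in the amide chain is expected to shift the number in this assay only modestly, if at all, probably toward a somewhat higher value. Compound 3 is therefore estimated at 15 nM, within 4 nM to 60 nM, meaning an expected step of a 2.5-fold higher number from compound 2 to compound 3 (0.40 log units; beyond the scatter).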

Compound 3, half-maximal inhibitory concentration: 4 nM
Beside the measured number, compound 3's estimate is 3.8-fold (0.57 log units) above it, and the stated range covers the measured number.
By their numbers in this assay, from the lowest: compounds 3 and 2 (each within the scatter of the next); then compound 1.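

In this assay, trimming propanoyl to acetyl gives a 1.5-fold lower number from compound 2 to compound 3 (0.18 log units; within the scatter) and so shows that the methyl at the end of the amide chain can be removed without a change distinguishable from the scatter. Compound 3 also provides a comparison with compound 1 that differs in one place: methyl in place of cyclopropyl on a saturated ring carbon gives an 89-fold lower number from compound 1 to compound 3 (1.95 log units; beyond the scatter) and places the large gap at that ring carbon rather than in the amide chain. Nothing measured here explains either result.

Only acetyl and propanoyl are shown on the amide, so the effect of a longer chain such as butanoyl remains open. At the ring carbon only methyl and cyclopropyl appear, leaving open how hydrogen or ethyl there would read.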